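The compounds below may be only part of what the source reports. "The series", "measured", "known", "first", "only" and "open" are said of these compounds alone.

Series notes. Three compounds have numbers in an assay on isolated protein for inhibition of histone deacetylase 8 (Homo sapiens); a lower number here means a stronger inhibitor, a higher number a weaker inhibitor. Compound 1 `COc1ccc(C(=O)c2ccc3c(ccn3Cc3ccc(C(=O)NO)cc3)c2)cc1OC` gives 756 nM. Compound 3 `O=C(NO)c1ccc(Cn2ccc3cc(C(=O)c4ccc(Cl)cc4)ccc32)cc1` gives 1060 nM; the step between them, a 1.4-fold higher number from compound 1 to compound 3 (0.15 log units; within the scatter), stays within the scatter. Compound 2 `COc1cccc(C(=O)c2ccc3c(ccn3S(=O)(=O)c3cccc(/C=C/C(=O)NO)c3)c2)c1` gives 3530 nM, the highest of the three numbers; its nearest neighbour on the numbers is compound 3, lower by a margin beyond the scatter, and compound 1 lies further off, also beyond the scatter.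

Compound 4 `COc1ccc(C(=O)c2ccc3c(ccn3S(=O)(=O)c3cccc(/C=C/C(=O)NO)c3)c2)cc1OC` is the unmeasured neighbour of compound 2. The change is methoxy in place of hydrogen on an aromatic carbon, that is 3-methoxyphenyl to 3,4-dimethoxyphenyl on the carbonyl. Going by the values given here, no measured pair isolates a methoxy-for-hydrogen swap. Among the compounds with values here, the only step touching the same region is a 1.4-fold higher number from compound 1 to compound 3 (0.15 log units; within the scatter), where 4-chlorophenyl replaced 3,4-dimethoxyphenyl on a carbonyl carbon without moving the number beyond the scatter; the parts of the structure that separate compound 2 from compounds 1 and 3 are the same in compound 2 and compound 4. The expected step in this assay is therefore one of no change beyond the scatter, a 1.2-fold lower number from compound 2 to compound 4 (0.07 log units; within the scatter). Compound 4 is estimated at 3000 nM, with a range from 1200 nM to 8000 nM.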

Compound 4, half-maximal inhibitory concentration: 1420 nM
Beside the measured number, compound 4's estimate is 2.1-fold (0.32 log units) above it; measured number inside the range.
By their numbers in this assay, from the lowest: compounds 1, 3 and 4 (each within the scatter of the next); then compound 2.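

Working notes: in this assay, methoxy in place of hydrogen on this aromatic carbon, ortho to a methoxy group and para to a large group, gives a 2.5-fold lower number from compound 2 to compound 4 (0.40 log units; beyond the scatter), a modest step. Going by these compounds alone, this is the first direct reading of a methoxy-for-hydrogen swap, and it shows that this single position on the aryl group of the carbonyl can move the number beyond the scatter. The only earlier change on that aryl group, a 1.4-fold higher number from compound 1 to compound 3 (0.15 log units; within the scatter), replaced the whole 3,4-dimethoxyphenyl group and stayed within the scatter, and nothing shown offers a reason for the gain from the added methoxy.

From the compounds shown here alone, it remains open whether this position favours methoxy specifically or whether a hydroxyl, ethoxy, fluorine or dimethylamino group on the same carbon would lower the number as far or further. Also open, going by these compounds, is whether the step carries over to the side chain of compound 1, since a single pair cannot show whether the same swap would act in the same direction when the rest of the structure differs.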